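The source may report more compounds than this note shows. Statements on the series, on what has been measured and on what is new or still open speak of the compounds shown alone.

Compound 1, `C=CCc1ccc(OC(=O)c2ccccc2Cl)c(OC)c1`: 2.79
Compound 2, `C=CCc1ccc(OC(=O)c2ccccc2C)c(OC)c1`: 2.87

For the measured compounds named here, in a physicochemical assay for lipophilicity (a higher number here means a more lipophilic compound, a lower number a more polar compound), compound 2 and compound 1 sit within the scatter of each other, the only measured step being a number 0.08 log units higher from compound 1 to compound 2 (within the scatter). Compound 3, `C=CCc1ccc(OC(=O)c2cccc(C)c2)c(OC)c1`, keeps the same atoms but joins them differently: 3-methylphenyl in place of 2-methylphenyl on a carbonyl carbon. Going by the values given here, no measured step rearranges the same atoms in this way, and the one step that is known, from a chloro to a methyl, stays within the scatter, so nothing in the data points to a shift beyond it. The step of a number 0.03 log units higher from compound 2 to compound 3 (within the scatter) is therefore expected to lie within the scatter. Compound 3 is estimated at 2.9, within a range from 2.6 to 3.2.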

Compound 3, partition coefficient: 2.87
For compound 3 the middle estimate is 0.03 log units above the measured one; low and high end bracket the measured number.
By their numbers in this assay, from the lowest: compounds 1, 2 and 3 (each within the scatter of the next).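

In this assay, for the compounds shown here, 3-methylphenyl in place of 2-methylphenyl on a carbonyl carbon gives no change at the digits printed from compound 2 to compound 3 (within the scatter) and so shows that this rearrangement of the same atoms, a kind of step the earlier compounds did not include, stays within the scatter. 3-Methylphenyl in place of 2-chlorophenyl at the same place gives a number 0.08 log units higher from compound 1 to compound 3 (within the scatter) and stays within it as well. No measurement at hand offers an explanation for this result. The compounds shown leave open whether an amine or a carboxylic acid on this aromatic ring would give a step beyond the scatter.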